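The compounds below may be only part of what the source reports. "The series", "measured", "known", "first", "only" and "open" are said of these compounds alone.

Compound 1 `CCCC(=O)C1=C(C)NC(=O)NC1c1ccco1`: 1% in an assay on membranes from HeLa cells for displacement of a labelled ligand from adenosine receptor A3 (Homo sapiens), read by scintillation counting, with a stated time of 180 min, tested at 1 uM; a higher number here means more inhibition at the concentration tested (going by the name of the read-out), a lower number less inhibition
Compound 2 `CCNC(=O)C1=C(C)NC(=O)NC1c1ccco1`: 3%
Compound 3 `CCN(CC)C(=O)C1=C(C)NC(=O)NC1c1ccco1`: 19%

Of the three numbers, compound 3 stands highest: the rise a number 16 percentage points higher from compound 2 to compound 3 (beyond the scatter) and the rise a number 18 percentage points higher from compound 1 to compound 3 (beyond the scatter) are both beyond the scatter, while the change a number 2 percentage points higher from compound 1 to compound 2 (within the scatter) lies within it. Compound 4 `CCC(CC)OC(=O)C1=C(C)NC(=O)NC1c1ccco1` differs from compound 3 in one place: (pentan-3-yl)oxy in place of diethylamino on a carbonyl carbon. Going by the values given here, no measured step exchanges an amide-type nitrogen for an oxygen on this carbonyl carbon, so none bears directly on the change. The two steps that end in compound 3 show only that what sits on this carbonyl carbon can move the inhibition by a modest amount, and that the compound carrying two ethyl groups on that position reads highest; compound 4 keeps two ethyl groups on a branched carbon but loses the nitrogen. Compound 4 is therefore expected to give roughly 10%, somewhere between 0% and 28%. The expected step of a number 9 percentage points lower from compound 3 to compound 4 (within the scatter) is a small fall, inside the scatter or just beyond it.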

Compound 4, a percentage reported as inhibition, at one concentration (the size of the read-out at that concentration, not a potency): 1%
Compound 4: the middle estimate sits 9 percentage points above what was measured; low and high end bracket the measured number.
By their numbers in this assay, from the lowest: compounds 1, 4 and 2 (each within the scatter of the next); then compound 3.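

In this assay, the exchange on the carbonyl carbon gives a number 18 percentage points lower from compound 3 to compound 4 (beyond the scatter), so keeping two ethyl groups on a branched carbon does not preserve the reading once the nitrogen is gone. Going by these compounds alone, the other two comparisons, a number 2 percentage points lower from compound 2 to compound 4 (within the scatter) and no change at the digits printed from compound 1 to compound 4 (within the scatter), place the (pentan-3-yl)oxy group level with the ethylamino and propyl groups, which leaves diethylamino as the only one of the four groups at this position that stands apart. No evidence is available to explain this difference.

The compounds shown leave open whether a larger dialkylamino group, such as dipropylamino, would match or exceed compound 3 on this carbonyl carbon. They also leave open whether a smaller ester group, such as ethoxy, would read any differently from compound 4.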